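A few compounds are considered here, and "the series" means these few. Any claim that something is new, unique, unknown or untested is made for them only; others in the source may bear on it.

Compound 2 `C=CCOC1=CS(=O)(=O)OC1(CC)Cc1ccccc1` shares its core with compound 1 `CCC1(Cc2ccccc2)OS(=O)(=O)C=C1OCCCCc1ccccc1`. In an ADME assay on HEL cells (Homo sapiens) for cytotoxicity, with a stated time of 3 days (on this read-out lower numbers stand for higher toxicity in this test and higher numbers for lower toxicity in this test), compound 1 gives 99000 nM. For compound 2, this assay reports only a limit, > 200000 nM, which is the limit described in the limit of > 200000 nM in this assay, at which 1 of the 2 values shown sits. Among the measured compounds shown here, the one measured step between them is an at least 2.0-fold higher number from compound 1 to compound 2 (0.30 log units; that floor lies within the scatter), and its floor does not go beyond the scatter. Compound 3 `CCC1(Cc2ccccc2)OS(=O)(=O)C=C1OCc1ccc(C)cc1` differs from compound 2 by 4-methylphenyl in place of vinyl on a saturated chain carbon bound to an oxygen on an unsaturated carbon, so an aromatic ring returns at the place where the step from compound 1 to compound 2 had removed one. For the measured compounds named here, that step is the only evidence bearing on this position, and since it showed nothing beyond the scatter, no large movement is expected in either direction. The estimated step of an at least 1.3-fold lower number from compound 2 to compound 3 (0.12 log units; that floor lies within the scatter) is therefore small. In this assay compound 3 is expected to give 150000 nM, within the range 60000 nM to 400000 nM.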

Compound 3, half-maximal cytotoxic concentration: 41500 nM
Compound 3: the middle estimate sits 3.6-fold (0.56 log units) above what was measured; measured number outside the range, below it.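

In this assay, the group on the saturated chain carbon bound to an oxygen on an unsaturated carbon does change the read-out, which the earlier step could not show, as its floor stayed within the scatter. Placing 4-methylphenyl there instead of vinyl gives an at least 4.8-fold lower number from compound 2 to compound 3 (0.68 log units; beyond the scatter), and placing it there instead of 3-phenylpropyl gives a 2.4-fold lower number from compound 1 to compound 3 (0.38 log units; beyond the scatter), so the presence of an aromatic ring at this place does not by itself fix the read-out. The first of these two steps is only a floor, and its full size stays unknown: the limit of > 200000 nM in this assay, at which 1 of the 3 values shown sits.

The compounds shown leave open whether the methyl group on the ring contributes to the lower number. They also leave open how a chain ending in an amine or a carboxylic acid would read at this place.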